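Swapping an allyl ether for an isopropyl ether

A few compounds are considered here, and "the series" means these few. Any claim that something is new, unique, unknown or untested is made for them only; others in the source may bear on it.

Of the compounds shown here, three of a shared core have been measured in an assay (Cricetulus griseus) for inhibition of aldehyde dehydrogenase, mitochondrial (Homo sapiens); on this read-out lower numbers stand for stronger inhibition and higher numbers for weaker inhibition. Compound 1, `C=CCCCCOc1ccc2c(=O)c(-c3ccc(O)cc3)coc2c1`, gives 150 nM. Compound 2, `O=C(O)COc1ccc2c(=O)c(-c3ccc(O)cc3)coc2c1`, gives 1200 nM. Compound 3, `C=CCOc1ccc2c(=O)c(-c3ccc(O)cc3)coc2c1`, gives 180 nM, which places compound 3 second highest among the three numbers, close to compound 1 and far from compound 2.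

The next compound, compound 4, `CC(C)Oc1ccc2c(=O)c(-c3ccc(O)cc3)coc2c1`, differs from compound 3 in one place: isopropyl in place of allyl on an oxygen on an aromatic ring. Two of the measured steps speak to it. The step of a 1.2-fold higher number from compound 1 to compound 3 (0.08 log units; within the scatter) shows that shortening the chain on the aromatic oxygen, while keeping a plain hydrocarbon there, leaves this assay essentially unchanged. The step of an 8.0-fold higher number from compound 1 to compound 2 (0.90 log units; beyond the scatter) shows that putting a carboxy group in that place weakens inhibition. Isopropyl, like allyl, is a plain hydrocarbon with no donors or acceptors and no charge, so the first step is the closer guide.

Compound 4 is therefore expected to give about 200 nM in this assay, with a likely range from 90 nM to 450 nM. The expected step is a 1.1-fold higher number from compound 3 to compound 4 (0.05 log units; within the scatter), which would lie within the usual scatter; no clear change in either direction is anticipated.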

Compound 4, half-maximal inhibitory concentration: 80 nM
The estimate for compound 4 lay 2.5-fold (0.40 log units) above the measured number; measured number below the stated range.
By their numbers in this assay, from the lowest: compounds 4, 1 and 3 (each within the scatter of the next, the first and the last beyond it); then compound 2.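

Going by these compounds alone, compound 3 and compound 4 carry groups with the same count of heavy atoms on the aromatic oxygen, yet in this assay the change from allyl to isopropyl gives a 2.3-fold lower number from compound 3 to compound 4 (0.35 log units; beyond the scatter) and is the first step between plain hydrocarbon groups at this position to lie beyond the scatter, so the shape of a small hydrocarbon group matters here, not only its size. The longer chain is not clearly separated from isopropyl, with a 1.9-fold lower number from compound 1 to compound 4 (0.27 log units; within the scatter) in the same assay, while the carboxymethyl group stands far apart, with a 15-fold lower number from compound 2 to compound 4 (1.18 log units; beyond the scatter) and the largest step in this set. Nothing available here explains why isopropyl and allyl differ.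

The compounds shown leave open whether the branch in isopropyl or the loss of the double bond in allyl accounts for the step, and a straight propyl group on the same oxygen would separate those two changes. Also open, from the compounds shown here alone, is how a cyclopropyl or tert-butyl group, or a chain ending in an amine, would behave at this position.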